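The compounds below may be only part of what the source reports. "The series", "measured", "known", "first", "only" and "open" are said of these compounds alone.

Compound 3 `Cc1cn(C2CC(N=[N+]=[N-])C(COC(=O)OCCCC(=O)OC(C)(C)C)O2)c(=O)[nH]c1=O` gives 0.267 h in an ADME assay on the whole organism (serum) with Homo sapiens as the target (a higher number here means that the compound lasts longer, a lower number that the compound disappears faster), the lowest of the three measured numbers. Its nearest neighbour is compound 1 `Cc1cn(C2CC(N=[N+]=[N-])C(COC(=O)CCCN)O2)c(=O)[nH]c1=O`, which gives 0.433 h in this assay, within the scatter of compound 3; furthest is compound 2 `Cc1cn(C2CC(N=[N+]=[N-])C(COC(=O)CCCC(=O)O)O2)c(=O)[nH]c1=O`, which gives 30 h, beyond the scatter. Compound 4 `Cc1cn(C2CC(N=[N+]=[N-])C(COC(=O)OCCCCO)O2)c(=O)[nH]c1=O` differs from compound 3 by hydroxymethyl in place of tert-butoxycarbonyl on a saturated chain carbon, three bonds along the chain from an oxygen next to a carbonyl group. For the measured compounds named here, the only measured step, a 69-fold higher number from compound 1 to compound 2 (1.84 log units; beyond the scatter), concerns a different change, carboxy in place of amino, and bears on this step only by showing that a change on the chain can move the number far. Going by the values given here, no measured pair shows tert-butoxycarbonyl against hydroxymethyl. With this weak footing, a modest step is expected, leaning toward a higher number, so compound 4 is expected to give a 1.9-fold higher number from compound 3 to compound 4 (0.27 log units; within the scatter). Compound 4 is therefore estimated at 0.5 h in this assay, with a range from 0.15 h to 2.5 h.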

Compound 4, half-life in the Homo sapiens assay: 0.5 h
Beside the measured number, compound 4's estimate shows no gap at the digits printed, and the stated range covers the measured number.
By their numbers in the Homo sapiens assay, from the lowest: compounds 3, 1 and 4 (each within the scatter of the next); then compound 2.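

On the saturated chain carbon, three bonds along the chain from an oxygen next to a carbonyl group, hydroxymethyl in place of tert-butoxycarbonyl does not separate the two compounds in the Homo sapiens assay: a 1.9-fold higher number from compound 3 to compound 4 (0.27 log units; within the scatter). In a physicochemical assay for lipophilicity (on this read-out lower numbers stand for lower lipophilicity and higher numbers for higher lipophilicity), the picture differs, for compound 3 gives 1.14 and compound 4 gives -0.68, so a large shift on this read-out comes with no half-life difference beyond the scatter. In the Homo sapiens assay, 4-hydroxybutoxy on a carbonyl carbon stays level with 3-aminopropyl, a 1.2-fold higher number from compound 1 to compound 4 (0.06 log units; within the scatter), but is far from 3-carboxypropyl, a 60-fold lower number from compound 2 to compound 4 (1.78 log units; beyond the scatter).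

The compounds shown leave open whether a carboxylic acid at the end of the chain of compound 3 would lengthen the half-life. They also leave open how a longer chain ending in hydroxyl would behave.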